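The source may hold more compounds than are shown below. What is called first, only, known or untested is meant among the compounds shown, and "the series" means these compounds.

Compound 2 `O=C(Nc1ccc(Cl)c(-c2nnc3c(Cl)cccn23)c1)c1ccccc1Cl` shares its core with two measured relatives. In a functional assay on MDA-MB-468 cells (Homo sapiens) for antiproliferative activity, read by MTT assay, with a stated time of 72 h (a higher number here means a weaker inhibitor, a lower number a stronger inhibitor), compound 2 gives only a limit of the assay, > 100000 nM, not a number. Compound 3 `O=C(Nc1ccc(Cl)c(-c2nnc3c(Cl)cccn23)c1)c1ccc(Cl)cc1` likewise reaches only a limit in this assay, > 100000 nM. Within the data shown here, compound 1 `O=C(Nc1ccc(Cl)c(-c2nnc3c(Cl)cccn23)c1)c1ccc(C(F)(F)F)cc1F`, which carries a different group on the carbonyl carbon, gives 22300 nM in this assay, the one finite value here. Among the measured compounds shown here, the sole step that touches compound 2 is a step that the two limits leave unreadable from compound 2 to compound 3, and it cannot be read because both values sit at the limit of > 100000 nM in this assay, at which 2 of the 3 values shown sit. Compound 4 `CS(=O)(=O)c1ccc(C(=O)Nc2ccc(Cl)c(-c3nnc4c(Cl)cccn34)c2)cc1` differs from compound 2 in one place: 4-(methylsulfonyl)phenyl in place of 2-chlorophenyl on a carbonyl carbon. For the measured compounds named here, no measured step tells how this group behaves, so the expectation rests on the picture that all three relatives are weak in this assay, one finite value and two limits. The step from compound 2 to compound 4 is therefore expected to be an at least 1.4-fold lower number from compound 2 to compound 4 (0.15 log units; that floor lies within the scatter), that is, small or unreadable. Compound 4 is estimated at 70000 nM in this assay, within a range from 15000 nM to 250000 nM, with a real chance that only a limit is reported again.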

Compound 4, half-maximal inhibitory concentration: > 100000 nM
Compound 4: a limit, no number (the forecaster's own chance of this, stated with the estimate: 50%); middle value at least 1.4-fold (0.15 log units) from the limit.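

No new step can be read between compound 4 and compound 2 or compound 3, because all three stop at the same limit rather than a number: the limit of > 100000 nM in this assay, at which 3 of the 4 values shown sit.

On these data alone, how strongly compound 2, compound 3 and compound 4 really act, and whether their different groups on the carbonyl carbon change that at all, stays open.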